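The compounds below may be only part of what the source reports. "The series", "measured", "known", "first", "only" and "open" are said of these compounds alone.

Measured values in an ADME assay on HepG2 cells (Homo sapiens) for cytotoxicity, with a stated time of 72 h; on this read-out higher numbers stand for an effect only at larger amounts of compound and lower numbers for an effect already at smaller amounts:

- compound 1, `Cc1cc(NC(=O)Nc2ccc(C)c(Cl)c2)c2ccccc2n1`: > 25000 nM, a limit of the assay
- compound 2, `Cc1ccc(NC(=O)Nc2cc(C)nc3ccccc23)cc1`: > 25000 nM, a limit of the assay
- compound 3, `Cc1cc(NC(=O)Nc2cc(Cl)cc(Cl)c2)c2ccccc2n1`: > 25000 nM, a limit of the assay

Compound 2 stands at the limit of this assay, and no number is known for it. The same holds for every value in the series, as the limit of > 25000 nM in this assay, at which 3 of the 3 values shown sit, records. Within the data shown here, the only pair differing in one place is compound 1 and compound 2, where hydrogen in place of chloro on an aromatic carbon gives a step that the two limits leave unreadable from compound 1 to compound 2; both ends are limits, so the size of that step cannot be read. Among the measured compounds shown here, for compound 3 only its limit is known; no step to it is given.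

Compound 4, `Cc1cc(NC(=O)Nc2ccc(C(F)(F)F)cc2)c2ccccc2n1`, is the next member. Relative to compound 2 the change is trifluoromethyl in place of methyl on an aromatic carbon.

For the measured compounds named here, no measured step bears on this change, and none of the three values gives a number to anchor a shift. With every value sitting at the limit, the expectation for compound 4 is that it also reaches the limit in this assay, and any step from compound 2 cannot be read as before. The estimated step is a step that the limit leaves unreadable from compound 2 to compound 4. The estimate for compound 4 is 30000 nM, with a range from 10000 nM to 100000 nM, the value most likely reported only as a limit.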

Compound 4, half-maximal effective concentration: 23000 nM
Compound 4: the middle estimate sits 1.3-fold (0.12 log units) above what was measured; measured number inside the range.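

In this assay, among these compounds, compound 4 gives 23000 nM, the first reading that is a number and not a limit of the assay, which places a trifluoromethyl compound with this substitution, on an aromatic carbon para to a large group, inside the range the assay can read. Trifluoromethyl in place of methyl at this position gives an at least 1.0-fold lower number from compound 2 to compound 4 (0.03 log units; that floor lies within the scatter); how far the true step lies beyond that floor cannot be read, since only one end of it is a number. The other compounds offer no number to set beside this one: the limit of > 25000 nM in this assay, at which 3 of the 4 values shown sit.

Going by these compounds, the step between the two limit compounds remains unreadable, so the effect of chloro on this read-out stays unknown, and a single number cannot show whether the cytotoxicity follows the group at this position or the trifluoromethyl alone. Also open, on these data alone, is how an amine, a carboxylic acid or a longer chain at the same aromatic carbon would read, and whether any such group would give a number or return to the limit.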